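The compounds below may be only part of what the source reports. "The series", "measured", "known", "first", "only" and "open" are said of these compounds alone.

Compound 1 `CCS(=O)(=O)Nc1cc(-c2ccc3ncnc(Nc4ccc(OC)cc4)c3c2)cnc1OC`: 3580 nM
Compound 2 `CCS(=O)(=O)Nc1cc(-c2ccc3ncnc(Nc4cccc(C(=O)OC)c4)c3c2)cnc1OC`: 1100 nM

Among the measured compounds shown here, in a functional assay on A549 cells (Homo sapiens) for cytotoxicity, read by sulforhodamine B assay, with a stated time of 72 h (on this read-out lower numbers stand for stronger inhibition and higher numbers for weaker inhibition), compound 1 gives 3580 nM, the higher of the two numbers known so far; compound 2 gives 1100 nM. The step of a 3.3-fold lower number from compound 1 to compound 2 (0.51 log units; beyond the scatter) is the only measured one. Compound 3 `CCS(=O)(=O)Nc1cc(-c2ccc3ncnc(Nc4ccc(Cl)c(C(=O)OC)c4)c3c2)cnc1OC` is made from compound 1 by the change (4-chloro-3-(methoxycarbonyl)phenyl in place of 4-methoxyphenyl on a nitrogen on an aromatic ring). This change contains the methoxycarbonyl swap already seen from compound 1 to compound 2, with a chlorine added, so a step of similar size and direction is expected, and compound 3 is estimated at 900 nM, between 300 nM and 2700 nM. The expected step is a 4.0-fold lower number from compound 1 to compound 3 (0.60 log units; beyond the scatter).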

Compound 3, half-maximal inhibitory concentration: 2130 nM
The estimate for compound 3 lay 2.4-fold (0.37 log units) below the measured number; the range from low to high includes it.
By their numbers in this assay, from the lowest: compounds 2, 3 and 1 (each within the scatter of the next, the first and the last beyond it).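

Chloro in place of hydrogen on an aromatic carbon gives a 1.9-fold higher number from compound 2 to compound 3 (0.29 log units; within the scatter) and so cannot be told apart from hydrogen here. The whole replacement on the nitrogen gives a 1.7-fold lower number from compound 1 to compound 3 (0.23 log units; within the scatter) and so leaves 4-chloro-3-(methoxycarbonyl)phenyl indistinguishable from 4-methoxyphenyl, even though compound 2 stays beyond the scatter of compound 1. No measurement at hand explains these numbers. Open, from the compounds shown here alone, is whether a carboxylic acid or an amide in place of the methyl ester, or fluoro or methyl in place of chloro, would shift the number beyond the scatter.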